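Bromo for Methoxy in a Cytotoxicity Series

This account rests on a few compounds, and the source may have more. Where it says the series, first, only, none or still open, it means among the compounds named here.

Of the compounds shown here, three have been measured in an ADME assay on HEK-293T cells (Homo sapiens) for cytotoxicity, read by MTT assay, with a stated time of 48 h, in the presence of a further agent that is not named here; a lower number here means a stronger inhibitor, a higher number a weaker inhibitor. Compound 1 `COc1ccc(NC(=O)c2csc(-c3cn(Cc4ccc(Cl)cc4)c4ccccc34)n2)cc1` gives > 100000 nM, which is a limit of the assay rather than a number. Compound 3 `O=C(Nc1ccccc1)c1csc(-c2c[nH]c3ccccc23)n1` likewise gives > 100000 nM, again a limit. Within the data shown here, compound 2 `COc1ccc2[nH]cc(-c3nc(C(=O)Nc4cc(OC)c(OC)c(OC)c4)cs3)c2c1` gives 8740 nM, the only number among the three values. Compound 1 and compound 3 both sit at a limit (the limit of > 100000 nM in this assay, at which 2 of the 3 values shown sit). Compound 4 `COc1cc(NC(=O)c2csc(-c3c[nH]c4ccc(Br)cc34)n2)cc(OC)c1OC` has not yet been measured; it differs from compound 2 by bromo in place of methoxy on an aromatic carbon. Among the measured compounds shown here, no step between measured compounds is available to guide this change, so the expectation is no shift beyond the scatter, an estimated step of a 1.1-fold higher number from compound 2 to compound 4 (0.06 log units; within the scatter). Compound 4 is therefore estimated at 10000 nM in this assay, with a range from 3000 nM to 50000 nM.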

Compound 4, half-maximal inhibitory concentration: 32800 nM
Beside the measured number, compound 4's estimate is 3.3-fold (0.52 log units) below it; the range from low to high includes it.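

In this assay, among these compounds, swapping methoxy for bromo on this aromatic carbon gives a 3.8-fold higher number from compound 2 to compound 4 (0.57 log units; beyond the scatter), so this position is not indifferent to the change, and this is the first step that can be read. Compound 1 and compound 3 add no number to this comparison, as each sits at a limit of the assay: the limit of > 100000 nM in this assay, at which 2 of the 4 values shown sit.

On these data alone, whether an amine or a hydroxyl at this same place would move the number in the same direction remains open. A single step also leaves open whether this shift would hold with a different group on the amide nitrogen.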